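Swapping a benzothiazole for a cyanofluorophenyl on two cores

A few compounds are considered here, and "the series" means these few. Any claim that something is new, unique, unknown or untested is made for them only; others in the source may bear on it.

Measured compounds:
compound 1, `CC(C)(C)OC(=O)N1CCN(C(=O)c2cn(-c3nc4ccccc4s3)nn2)CC1`, 7.12 nM
compound 2, `CC(C)(C)OC(=O)N1CCN(C(=O)c2cn(-c3ccc(C#N)cc3F)nn2)CC1`, 4.21 nM
compound 3, `CC(C)(C)OC(=O)N1CCC(OC(=O)c2cn(-c3nc4ccccc4s3)nn2)CC1`, 8.17 nM

In an assay on HEK293 cells for agonist activity at Glucose-dependent insulinotropic receptor (Homo sapiens), read by a luciferase reporter, with a stated time of 24 h (on this read-out higher numbers stand for an effect only at larger amounts of compound and lower numbers for an effect already at smaller amounts), compound 1 gives 7.12 nM, compound 2 gives 4.21 nM, and compound 3 gives 8.17 nM. The change from compound 1 to compound 2, (4-cyano-2-fluorophenyl in place of 1,3-benzothiazol-2-yl on an aromatic nitrogen), made a step of a 1.7-fold lower number from compound 1 to compound 2 (0.23 log units; within the scatter). The difference between the core of compound 1 and the core of compound 3 is not broken down here. Compound 4, `CC(C)(C)OC(=O)N1CCC(OC(=O)c2cn(-c3ccc(C#N)cc3F)nn2)CC1`, carries the same change on the core of compound 3: 4-cyano-2-fluorophenyl in place of 1,3-benzothiazol-2-yl on an aromatic nitrogen. Because the step of a 1.7-fold lower number from compound 1 to compound 2 (0.23 log units; within the scatter) stayed within the scatter, a step of similar size is expected here too. The expected step from compound 3 to compound 4 is a 1.7-fold lower number from compound 3 to compound 4 (0.23 log units; within the scatter). Compound 4 is therefore estimated at 4.8 nM in this assay, with a likely range from 2 nM to 12 nM.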

Compound 4, half-maximal effective concentration: 3.59 nM
Compound 4: middle estimate off by 1.3-fold (0.13 log units), on the high side; low and high end bracket the measured number.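

On the core of compound 3, the swap to 4-cyano-2-fluorophenyl gives a step of a 2.3-fold lower number from compound 3 to compound 4 (0.36 log units; beyond the scatter) in this assay. Set beside the earlier step, the change carries across these two cores without a difference in size that can be told apart from scatter: the same change on two cores in this assay, a 1.7-fold lower number (0.23 log units; within the scatter) from compound 1 to compound 2 and a 2.3-fold lower number (0.36 log units; beyond the scatter) from compound 3 to compound 4, 1.3-fold (0.13 log units) apart, within the scatter of two such steps

Within the data shown here, this is one change on only two cores, so it does not show that the step would hold on other cores, and it does not explain why the number moves.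

Still open, going by these compounds, is how the same swap would behave on a core with a free amine in place of the tert-butyl carbamate. Also open, on these data alone, is how an unsubstituted phenyl on that aromatic nitrogen would compare.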